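Dimethylamino in place of a pyrrolidinyl amide on the shared core

A few compounds are considered here, and "the series" means these few. Any claim that something is new, unique, unknown or untested is made for them only; others in the source may bear on it.

Measured so far:
compound 1 `CC(C)N(C)c1ccc2cc(NC(=O)CCc3ccc(C(F)(F)F)cc3)ccc2n1` in an assay on isolated protein for displacement of a labelled ligand from melanin-concentrating hormone receptor 1 (Homo sapiens) (on this read-out higher numbers stand for weaker inhibition and lower numbers for stronger inhibition), gives 2 nM
compound 2 `CC(C)C(=O)NC1CCN(c2ccc3cc(NC(=O)CCc4ccc(C(F)(F)F)cc4)ccc3n2)C1` in this assay gives 1 nM

Compound 2 holds the lowest of the two numbers, with compound 1 standing a 2.0-fold lower number from compound 1 to compound 2 (0.30 log units; within the scatter) away from it, so the two are not separated. Compound 3 `CN(C)c1ccc2cc(NC(=O)CCc3ccc(C(F)(F)F)cc3)ccc2n1` differs from compound 2 by dimethylamino in place of 3-((isopropylcarbonyl)amino)pyrrolidin-1-yl on an aromatic carbon. Among the measured compounds shown here, the only measured step that bears on this position, a 2.0-fold lower number from compound 1 to compound 2 (0.30 log units; within the scatter), shows that a large change at this amine left the number within the scatter. No change beyond the scatter is therefore expected for compound 3 in this assay, and its value is estimated at 3 nM (range 1 nM to 12 nM), a step of a 3.0-fold higher number from compound 2 to compound 3 (0.48 log units; beyond the scatter).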

Compound 3, half-maximal inhibitory concentration: 13 nM
Beside the measured number, compound 3's estimate is 4.3-fold (0.64 log units) below it; the whole stated range lies below it.
By their numbers in this assay, from the lowest: compounds 2 and 1 (each within the scatter of the next); then compound 3.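

In this assay this position proves sensitive after all: dimethylamino in place of 3-((isopropylcarbonyl)amino)pyrrolidin-1-yl brings a 13-fold higher number from compound 2 to compound 3 (1.11 log units; beyond the scatter) and so a change beyond the scatter, which the earlier pair did not show. Methyl in place of isopropyl on the same nitrogen alone brings a 6.5-fold higher number from compound 1 to compound 3 (0.81 log units; beyond the scatter) and is also beyond the scatter, so the loss already appears with this single change. Nothing available gives a reason for either step. On these data alone, whether ethyl on that nitrogen, or a plain pyrrolidin-1-yl without the amide, would bring the number back down stays open.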